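Anilino analogue of the cyclopentylamino compound: expected potency

The source may report more compounds than this note shows. Statements on the series, on what has been measured and on what is new or still open speak of the compounds shown alone.

The series shares one core and varies the substituent on an amine nitrogen. Compound 1 `O=C1C(Nc2cccc(Cl)c2)=CC(=O)c2c1nc1n2[C@H]2OC[C@@H](O)[C@H]2OC1` carries a 3-chlorophenyl there, and in a functional assay on HeLa cells (Homo sapiens) for inhibition, read by sulforhodamine B assay (on this read-out higher numbers stand for weaker inhibition and lower numbers for stronger inhibition), compound 1 gives 7970 nM. Compound 2 `CCOc1ccc(NC2=CC(=O)c3c(nc4n3[C@H]3OC[C@@H](O)[C@H]3OC4)C2=O)cc1` carries a 4-ethoxyphenyl, and in this assay compound 2 gives 14400 nM; the step of a 1.8-fold higher number from compound 1 to compound 2 (0.26 log units; within the scatter) is small. Compound 3 `O=C1C(NC2CCCC2)=CC(=O)c2c1nc1n2[C@H]2OC[C@@H](O)[C@H]2OC1` carries a cyclopentyl. For compound 3 the assay reports only a limit, > 16000 nM, so its place among the three is known only as a floor: the steps of an at least 2.0-fold higher number from compound 1 to compound 3 (0.30 log units; that floor lies within the scatter) and an at least 1.1-fold higher number from compound 2 to compound 3 (0.04 log units; that floor lies within the scatter) show that compound 3 sits no lower than its two aryl relatives, consistent with the limit of > 16000 nM in this assay, at which 1 of the 3 values shown sits.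

Compound 4 `O=C1C(Nc2ccccc2)=CC(=O)c2c1nc1n2[C@H]2OC[C@@H](O)[C@H]2OC1` is the next member. The change from compound 3 is phenyl in place of cyclopentyl on an amine nitrogen. Both measured steps that lead to compound 3 move from an aryl group to cyclopentyl and both give a higher number or a limit; compound 4 reverses that direction, going back to an aryl group. The expectation is therefore a return toward the numbers of compound 1 and compound 2 rather than a change beyond the scatter in the other direction: the estimated step is an at least 1.6-fold lower number from compound 3 to compound 4 (0.20 log units; that floor lies within the scatter). Compound 4 is thus expected to give about 10000 nM in this assay, with a likely range from 4000 nM to 25000 nM.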

Compound 4, half-maximal inhibitory concentration: > 8000 nM
Compound 4 was reported as a limit; the forecaster's own chance of this, stated with the estimate: 30%; the middle value does not contradict the limit.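

Compound 4 is reported only as a limit of the assay, not as a number: the limit of > 8000 nM in this assay, at which 1 of the 4 values shown sits. With hydrogen in place of chloro on an aromatic carbon, the result is a number no lower from compound 1 to compound 4 (the limit leaves the size open), so in this assay the unsubstituted phenyl on the amine nitrogen shows no gain over the 3-chlorophenyl of compound 1, while the steps from compound 2 and from compound 3 to compound 4 cannot be read. Having an aryl group on this nitrogen is also not enough to give a numerical value, since compound 4, like the cyclopentyl compound 3, stops at a limit, and among these four compounds only the substituted phenyl rings of compound 1 and compound 2 give numbers.

The compounds shown leave open where compound 4 truly lies, and therefore whether the chloro or ethoxy group on the phenyl ring contributes anything to the values of compound 1 and compound 2. They also leave open how the series would respond to a carboxylic acid or an amine on that phenyl ring, or to a longer alkyl chain on the amine nitrogen in place of the ring.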